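Fluoro for Methyl on the Sulfonyl Aryl Ring

A few compounds are considered here, and "the series" means these few. Any claim that something is new, unique, unknown or untested is made for them only; others in the source may bear on it.

Compound 1, `COc1ccc(S(=O)(=O)c2cnc3ccc(F)cc3c2N2CCC(C)CC2)cc1`, gives 85% in an assay on isolated protein for displacement of a labelled ligand from metabotropic glutamate receptor 5 (Homo sapiens), with a stated time of 60 min, tested at 1 uM; a higher number here means more inhibition at the concentration tested (going by the name of the read-out), a lower number less inhibition.
Compound 2, `Cc1ccc2ncc(S(=O)(=O)c3ccc(C)c(Cl)c3)c(N3CCC(C)CC3)c2c1`, gives 91% in this assay.
Compound 3, `Cc1ccc(S(=O)(=O)c2cnc3ccc(F)cc3c2N2CCC(C)CC2)cc1Cl`, gives 91% in this assay.

Compound 2 is level with compound 3 at the digits shown, and together they are the highest of the three numbers; the one measured step that reaches down to the lowest number is a number 6 percentage points higher from compound 1 to compound 3 (within the scatter), so all three sit within the scatter of one another.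

Compound 4, `Cc1ccc2ncc(S(=O)(=O)c3ccc(F)c(Cl)c3)c(N3CCC(C)CC3)c2c1`, has not been measured. It differs from compound 2 in one place: fluoro in place of methyl on an aromatic carbon.

Among the measured compounds shown here, two measured steps bear on this. The swap of fluoro for methyl on an aromatic carbon of the shared core gave no change at the digits printed from compound 2 to compound 3 (within the scatter). Changing the group on the sulfonyl sulfur from 4-methoxyphenyl to 3-chloro-4-methylphenyl gave a number 6 percentage points higher from compound 1 to compound 3 (within the scatter). Neither step left the scatter, so no step beyond the scatter is expected here either.

Compound 4 is therefore expected to give about 88% in this assay, between 75% and 96%. The expected step is a number 3 percentage points lower from compound 2 to compound 4 (within the scatter).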

Compound 4, a percentage reported as inhibition, at one concentration (the size of the read-out at that concentration, not a potency): 93%
The estimate for compound 4 lay 5 percentage points below the measured number; the range from low to high includes it.
By their numbers in this assay, from the lowest: compounds 1, 2, 3 and 4 (each within the scatter of the next).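

In this assay, fluoro in place of methyl on the sulfonyl aryl ring, ortho to a chloro group and para to a large group, gives a number 2 percentage points higher from compound 2 to compound 4 (within the scatter). The same swap on the shared core gave no change at the digits printed from compound 2 to compound 3 (within the scatter), so among these compounds the change stays within the scatter in both places, and this position accepts fluoro as well as methyl with the chloro group kept. No measurement shown here offers an explanation for this result.

As far as these compounds go, a reading at one concentration is not a potency, so any difference in potency between compound 2 and compound 4 remains unknown. Also open, from the compounds shown here alone, is whether a larger or charged group at this position, such as a trifluoromethyl group, an amine or a carboxylic acid, would keep the inhibition this high.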